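Ester chain extension from compound 3 to compound 4

The source may report more compounds than this note shows. Statements on the series, on what has been measured and on what is new or still open speak of the compounds shown alone.

Values in a toxicity assay on MRC5 cells (Homo sapiens) for inhibition, read by MTT assay, with a stated time of 72 h; a higher number here means a weaker inhibitor, a lower number a stronger inhibitor
- compound 1 `CCCCCCCCCCCCCC(=O)OCCc1ccc(O)c(O)c1` gives > 50000 nM (a limit)
- compound 2 `CCCCCCCCCCCC(=O)OCCc1ccc(O)cc1` gives 67200 nM
- compound 3 `CCCCCCCC(=O)OCCc1ccc(O)c(O)c1` gives 104000 nM

Compound 3, at 104000 nM, lies within the scatter of compound 2, at 67200 nM, so these two numbers set no order. Compound 1 is known only as a limit, > 50000 nM.

Compound 4 `CCCCCCCCCCCC(=O)OCCc1ccc(O)c(O)c1` carries butyl in place of hydrogen on a saturated chain carbon, seven bonds along the chain from a carbonyl carbon. For the measured compounds named here, the one measured step on this chain, a step that the limit leaves unreadable from compound 1 to compound 3, gives no usable size. Compound 2, at 67200 nM, shares its chain with compound 4 but has a different core. With so little to go on, no shift beyond the scatter is expected in this assay, and any shift would more likely be towards a lower number. The expected step is a 1.4-fold lower number from compound 3 to compound 4 (0.14 log units; within the scatter). Compound 4 could also be reported only as a limit, given (the limit of > 50000 nM in this assay, at which 1 of the 3 values shown sits). Compound 4 is estimated at 75000 nM, with an expected range of 35000 nM to 150000 nM.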

Compound 4, half-maximal inhibitory concentration: 38100 nM
Compound 4: the middle estimate sits 2.0-fold (0.29 log units) above what was measured; measured number inside the range.
By their numbers in this assay, from the lowest: compounds 4, 2 and 3 (each within the scatter of the next, the first and the last beyond it).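

In this assay, for the compounds shown here, butyl in place of hydrogen on this saturated chain carbon gives the first readable step on the chain: a 2.7-fold lower number from compound 3 to compound 4 (0.44 log units; beyond the scatter). Hydroxy in place of hydrogen on an aromatic carbon sets no order, with a step inside the scatter: a 1.8-fold lower number from compound 2 to compound 4 (0.25 log units; within the scatter). Hydrogen in place of ethyl further along the chain gives only a floor, a value resting on a limit and not on a number, an at least 1.3-fold lower number from compound 1 to compound 4 (0.11 log units; that floor lies within the scatter): the limit of > 50000 nM in this assay, at which 1 of the 4 values shown sits.

Whether chains beyond that of compound 4 continue the shift to a lower number stays open, as the longest chain shown is known only as a limit. Going by these compounds, how an amine or a carboxylic acid at the far end of the chain would read also stays open.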